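Trifluoromethoxy for trifluoromethyl on the aryl ether

A few compounds are considered here, and "the series" means these few. Any claim that something is new, unique, unknown or untested is made for them only; others in the source may bear on it.

Measured compounds:
compound 1 `O=C(O)c1csc([C@H]2CC[C@@H]3[C@@H](COc4ccc(C(F)(F)F)cc4)[C@H](O)C[C@@H]3O2)n1`: 13 nM
compound 2 `O=C(O)c1csc([C@H]2CC[C@@H]3[C@@H](/C=C/COc4ccccc4)[C@H](O)C[C@@H]3O2)n1`: 3.8 nM

In a functional assay on CHO cells for agonist activity at prostaglandin E2 receptor EP2 subtype (Homo sapiens), read by HTRF and cAMP accumulation, with a stated time of 30 min (on this read-out lower numbers stand for an effect already at smaller amounts and higher numbers for an effect only at larger amounts of compound), compound 1 gives 13 nM and holds the highest of the two numbers; compound 2 gives 3.8 nM, a lower number beyond the scatter. No one-site comparison exists between these two.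

Compound 3 `O=C(O)c1csc([C@H]2CC[C@@H]3[C@@H](COc4ccc(OC(F)(F)F)cc4)[C@H](O)C[C@@H]3O2)n1` is unmeasured. It differs from compound 1 by trifluoromethoxy in place of trifluoromethyl on an aromatic carbon. Among the compounds with values here, no step for this kind of change is available. The expected step from compound 1 to compound 3 is a 1.1-fold lower number from compound 1 to compound 3 (0.03 log units; within the scatter), with no shift beyond the scatter anticipated in either direction. Compound 3 is therefore estimated at 12 nM, within a range of 4 nM to 40 nM.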

Compound 3, half-maximal effective concentration: 14 nM
Compound 3: middle estimate off by 1.2-fold (0.07 log units), on the low side, within the range that was stated.
By their numbers in this assay, from the lowest: compound 2; then compounds 1 and 3 (each within the scatter of the next).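

In this assay, within the data shown here, trifluoromethoxy in place of trifluoromethyl on the aromatic carbon para to a large group gives a 1.1-fold higher number from compound 1 to compound 3 (0.03 log units; within the scatter) and provides the first one-site comparison. At this position, the exchange therefore leaves the number within the scatter, despite the added oxygen and its hydrogen-bond acceptor. No measured property is available to explain this result.

Open, on these data alone, is whether a nitrile, a methoxy group or chlorine at this place would also stay within the scatter of compound 1. Also open, as far as these compounds go, is whether trifluoromethoxy would behave the same way on the longer chain of compound 2.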